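The source may hold more compounds than are shown below. What is called first, only, known or untested is meant among the compounds shown, and "the series" means these compounds.

Compound 1 `CCCCCCCCS(=O)(=O)Nc1ccc(-c2ccc(Cl)cc2)cc1C(=O)O` gives 9200 nM in an assay on mitochondria (strain BALB/c) for inhibition of glycerol-3-phosphate acyltransferase 1, mitochondrial (Mus musculus), read by scintillation counting, with a stated time of 10 min; on this read-out higher numbers stand for weaker inhibition and lower numbers for stronger inhibition.
Compound 2 `CCCCCCCCS(=O)(=O)Nc1ccc(-c2ccccc2-c2ccccc2)cc1C(=O)O` gives 10100 nM in this assay.

On the numbers shown, compound 2 sits beside compound 1: the gap between the two values lies within the scatter, so neither can be told apart from the other. Compound 3 `CCCCCCCCS(=O)(=O)Nc1ccc(-c2ccccc2OC)cc1C(=O)O` differs from compound 2 by methoxy in place of phenyl on an aromatic carbon. Going by the values given here, no measured pair shows this change, so its effect is unknown; with the two measured values close together, compound 3 is expected to shift only a little in this assay, a step of a 1.2-fold higher number from compound 2 to compound 3 (0.07 log units; within the scatter) being estimated, none beyond the scatter. For compound 3 a value of 12000 nM is estimated, within a range from 4000 nM to 36000 nM.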

Compound 3, half-maximal inhibitory concentration: 27600 nM
Estimate against measurement, compound 3: 2.3-fold (0.36 log units) below; low and high end bracket the measured number.
By their numbers in this assay, from the lowest: compounds 1 and 2 (each within the scatter of the next); then compound 3.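

In this assay, going by these compounds alone, methoxy in place of phenyl on an aromatic carbon, ortho to a large group, gives a 2.7-fold higher number from compound 2 to compound 3 (0.44 log units; beyond the scatter), the first change here to go beyond the scatter, whereas compounds 1 and 2 could not be told apart. Setting 2-methoxyphenyl in place of 4-chlorophenyl gives a 3.0-fold higher number from compound 1 to compound 3 (0.48 log units; beyond the scatter), also modest and towards weaker inhibition. Nothing available explains this weakening. From the compounds shown here alone, whether the step comes from phenyl leaving or methoxy entering remains open, as does whether a hydroxyl or an amine at this place would behave like methoxy.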